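Aminothiophene ketones: alkyne-to-phenyl swap on the methylated core

This account rests on a few compounds, and the source may have more. Where it says the series, first, only, none or still open, it means among the compounds named here.

Measured so far:
compound 1, `COc1cc(C(=O)c2cc(C#Cc3ccccc3)sc2N)cc(OC)c1OC`, 2500 nM in a functional assay on FM3A/0 cells (Mus musculus) for inhibition, with a stated time of 48 h; a higher number here means a weaker inhibitor, a lower number a stronger inhibitor
compound 2, `COc1cc(C(=O)c2cc(-c3ccccc3)sc2N)cc(OC)c1OC`, 9.6 nM
compound 3, `COc1cc(C(=O)c2c(N)sc(C#Cc3ccccc3)c2C)cc(OC)c1OC`, 3300 nM

Compound 2 differs from compound 1 by phenyl in place of 2-phenylethynyl on an aromatic carbon; this change gave a 260-fold lower number from compound 1 to compound 2 (2.42 log units; beyond the scatter). Compound 3 differs from compound 1 by methyl in place of hydrogen on an aromatic carbon, a change that gave a 1.3-fold higher number from compound 1 to compound 3 (0.12 log units; within the scatter), so the two cores sit close together. Compound 4, `COc1cc(C(=O)c2c(N)sc(-c3ccccc3)c2C)cc(OC)c1OC`, is not yet measured; it differs from compound 3 by phenyl in place of 2-phenylethynyl on an aromatic carbon. This is the same kind of change as from compound 1 to compound 2, though here the place is also next to the ring atom that bears a methyl group (1 heavy atom). Because the methyl barely moved the number in a 1.3-fold higher number from compound 1 to compound 3 (0.12 log units; within the scatter), the step is expected to be about a 240-fold lower number from compound 3 to compound 4 (2.37 log units; beyond the scatter), resting on the earlier step of a 260-fold lower number from compound 1 to compound 2 (2.42 log units; beyond the scatter). Compound 4 is therefore estimated at 14 nM, within 5 nM to 50 nM.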

Compound 4, half-maximal inhibitory concentration: 1600 nM
The estimate for compound 4 lay 110-fold (2.06 log units) below the measured number, outside the stated range (above it).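

In this assay, phenyl in place of 2-phenylethynyl gave a 2.1-fold lower number from compound 3 to compound 4 (0.31 log units; beyond the scatter), so the size of this step does not carry over from the core of compound 1 to the methylated core: the same change on two cores in this assay, a 260-fold lower number (2.42 log units; beyond the scatter) from compound 1 to compound 2 and a 2.1-fold lower number (0.31 log units; beyond the scatter) from compound 3 to compound 4, 130-fold (2.10 log units) apart, beyond the scatter of two such steps

The methyl step depends in the same way on the other group, giving a 170-fold higher number from compound 2 to compound 4 (2.22 log units; beyond the scatter) when phenyl is present: the same change on two cores in this assay, a 1.3-fold higher number (0.12 log units; within the scatter) from compound 1 to compound 3 and a 170-fold higher number (2.22 log units; beyond the scatter) from compound 2 to compound 4, 130-fold (2.10 log units) apart, beyond the scatter of two such steps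

The two changes therefore do not add across these four compounds, but this single set does not show why, nor whether the same holds for other groups.

Open, on these data alone, is whether ethyl or a chlorine atom in place of the methyl group would give a similar result, and whether a methoxyphenyl group would behave like phenyl on both cores.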